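A few compounds are considered here, and "the series" means these few. Any claim that something is new, unique, unknown or untested is made for them only; others in the source may bear on it.

Measured so far:
compound 1, `Cn1c(Cc2nn(C)c(=O)c3ccccc23)nnc1SCCCCCCCC(=O)Nc1ccc(Cl)cc1Cl` — 19100 nM
compound 2, `Cn1c(Cc2nn(C)c(=O)c3ccccc23)nnc1SCCCCCCCCCCC(=O)Nc1ccc(Cl)cc1Cl` — "not determined" (no result reported)

For the measured compounds named here, compound 1 is the only member of this small set with a number in an assay on isolated protein for binding affinity to interleukin-15 (Homo sapiens), read by surface plasmon resonance; a higher number here means weaker binding, a lower number tighter binding; there compound 1 gives 19100 nM, and with nothing else measured it stands alone, neither strongest nor weakest by comparison. Compound 2 carries a longer chain to the same anilide, but no result was reported for it, so it offers no point of comparison. Compound 3, `Cn1c(Cc2nn(C)c(=O)c3ccccc23)nnc1SCCCCCCCC(=O)Nc1ccc(Br)cc1Br`, has not yet been measured. It differs from compound 1 in one place: 2,4-dibromophenyl in place of 2,4-dichlorophenyl on an amide-type nitrogen. Going by the values given here, no pair of measured compounds shows what this exchange does, so the size of the step rests on expectation alone. Bromine in place of chlorine on the same ring is an exchange that, in the absence of any measured guide, is expected to move the reading little, in either direction. The change is expected to amount to a 1.3-fold lower number from compound 1 to compound 3 (0.10 log units; within the scatter), a step within the usual scatter. Compound 3 is accordingly expected to give about 15000 nM, most likely between 6000 nM and 40000 nM.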

Compound 3, dissociation constant: 11600 nM
Compound 3: middle estimate off by 1.3-fold (0.11 log units), on the high side; measured number inside the range.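

In this assay, 2,4-dibromophenyl in place of 2,4-dichlorophenyl on an amide-type nitrogen gives a 1.6-fold lower number from compound 1 to compound 3 (0.22 log units; within the scatter), a step that lies within the usual scatter of repeated measurements. For the compounds shown here, this is the first measured step at this position, and it shows that this exchange does not separate compound 3 from compound 1, although the two groups differ in their halogen while matching in heavy atoms, ring, hydrogen-bond donors and acceptors, and charge. Nothing at hand explains why the two groups read alike.

The compounds shown leave open whether any group on this nitrogen can move the reading beyond the scatter, for instance an unsubstituted phenyl, a methoxyphenyl, or a phenyl ring carrying a carboxylic acid or an amine in place of the two halogens. They also leave open how the reading responds to a shorter or longer chain between the shared core and the amide carbonyl, since a single step at one position says nothing about the rest of the molecule.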